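Chloro in Place of Methoxy: Expecting Compound 4

The source may hold more compounds than are shown below. What is called first, only, known or untested is meant among the compounds shown, and "the series" means these compounds.

Of the compounds shown here, three sharing one core have been measured in a functional assay on PANC-1 cells (Homo sapiens) for inhibition, read by MTT assay, with a stated time of 24 h, tested at 10 uM; on this read-out lower numbers stand for less inhibition and higher numbers for more inhibition at the one concentration tested (going by the name of the read-out). Compound 1 `CC(C)=CCC/C(C)=C/CC1Cc2c(OCc3ccccc3)cc(=O)n(CCCO)c2CC1(C)C` gives 46.5%. Compound 2 `CC(C)=CCC/C(C)=C/CC1Cc2c(OCC=C(C)C)cc(=O)n(CCCO)c2CC1(C)C` gives 30.3%, and compound 3 `COc1ccc(NC(=O)Oc2cc(=O)n(CCCO)c3c2CC(C/C=C(\C)CCC=C(C)C)C(C)(C)C3)cc1` gives 64.1%. Compound 3 stands highest of the three: the step of a number 17.6 percentage points higher from compound 1 to compound 3 (beyond the scatter) is modest, and the step of a number 33.8 percentage points higher from compound 2 to compound 3 (beyond the scatter) is large, while a number 16.2 percentage points lower from compound 1 to compound 2 (beyond the scatter) runs the other way. Both steps leading to compound 3 concern the group on the ring oxygen, not the substituent on the outer aromatic ring.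

Compound 4 `CC(C)=CCC/C(C)=C/CC1Cc2c(OC(=O)Nc3ccc(Cl)cc3)cc(=O)n(CCCO)c2CC1(C)C` keeps the (4-methoxyphenyl)carbamoyl arrangement of compound 3 but alters its far end: chloro in place of methoxy on an aromatic carbon. Within the data shown here, no measured step changes this position, so the record offers no direct guide, and the expectation is for a step within the scatter, a number 4.1 percentage points lower from compound 3 to compound 4 (within the scatter). Compound 4 is therefore estimated at 60% in this assay, with a range from 45% to 75%.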

Compound 4, a percentage reported as inhibition, at one concentration (the size of the read-out at that concentration, not a potency): 47.2%
The estimate for compound 4 lay 12.8 percentage points above the measured number, and the stated range covers the measured number.
By their numbers in this assay, from the lowest: compound 2; then compounds 1 and 4 (each within the scatter of the next); then compound 3.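

In this assay the far end of the carbamoyl group proves not to be a silent position: chloro in place of methoxy on this aromatic carbon gives a number 16.9 percentage points lower from compound 3 to compound 4 (beyond the scatter) and so takes away part of what compound 3 had gained. The step from benzyl to (4-chlorophenyl)carbamoyl on the ring oxygen gives a number 0.7 percentage points higher from compound 1 to compound 4 (within the scatter), so among these compounds the lead of the carbamoyl over benzyl appears only with methoxy in place. Over 3-methylbut-2-en-1-yl the carbamoyl still holds a lead with chloro, as the step to a number 16.9 percentage points higher from compound 2 to compound 4 (beyond the scatter) shows, and nothing available accounts for the difference between methoxy and chloro.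

Going by these compounds, whether the oxygen of methoxy or merely its size matters remains open. An ethoxy, a hydroxy or a dimethylamino group on the same aromatic carbon would bear on that question.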